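This account rests on a few compounds, and the source may have more. Where it says the series, first, only, none or still open, it means among the compounds named here.

Measured so far in a functional assay on SK-N-MC cells (Homo sapiens) for cytotoxicity, read by MTT assay, with a stated time of 72 h; on this read-out lower numbers stand for stronger inhibition and higher numbers for weaker inhibition:

Compound 1 `O=C(/C=C/c1ccc(Cl)cc1Cl)c1cc(Cl)ccc1O`: 69800 nM
Compound 2 `O=C(/C=C/c1cccc(Cl)c1)c1cc(Cl)ccc1O`: 47800 nM

Going by the values given here, with only two numbers available, compound 1 cannot be told apart from compound 2, since the two values lie within the usual scatter of repeated measurements. Neither can be ranked above the other.

The next compound to be tested is compound 3 `O=C(/C=C/c1ccccc1Cl)c1cc(Cl)ccc1O`. Compared with compound 1, the change is hydrogen in place of chloro on an aromatic carbon. Put simply, hydrogen stands in place of chloro on an aromatic carbon.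

Among the compounds with values here, no measured pair yet shows what a single change of this kind does in this assay. Within the data shown here, the only guide is that compound 1 gives 69800 nM and compound 2 gives 47800 nM, which are values within the scatter of each other. No step beyond the scatter is therefore expected.

The estimated step is a 1.4-fold lower number from compound 1 to compound 3 (0.14 log units; within the scatter).

For compound 3 the expected value is 50000 nM, with an estimated range of 22000 nM to 110000 nM.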

Compound 3, half-maximal inhibitory concentration: 51300 nM
Estimate against measurement, compound 3: 1.0-fold (0.01 log units) below; measured number inside the range.
By their numbers in this assay, from the lowest: compounds 2, 3 and 1 (each within the scatter of the next).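

Going by these compounds alone, the first pair that differs in only one place gives, in this assay, a 1.4-fold lower number from compound 1 to compound 3 (0.13 log units; within the scatter). So putting hydrogen in place of chloro on this aromatic carbon, para to a large group, produces no change that can be told apart from the normal spread of repeated measurements, and the chloro group at this carbon is not shown to matter in this assay. No measurement here offers any explanation for this result.

Still open, from the compounds shown here alone, is whether a different group on this same carbon, such as an amine, a carboxylic acid or a longer carbon chain, would give a step beyond the scatter. Also open, going by these compounds, is what happens when the chloro group that remains on this ring is replaced.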